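The source may report more compounds than this note shows. Statements on the series, on what has been measured and on what is new or still open speak of the compounds shown alone.

Compound 1 `Fc1ccc(-c2cn3nc(Cc4ccc(Cl)cc4)sc3n2)cc1` was examined in a functional assay on L1210 cells (Mus musculus) for cytotoxicity, with a stated time of 48 h; on this read-out lower numbers stand for stronger inhibition and higher numbers for weaker inhibition. In this assay compound 1 gives > 250000 nM, which is a limit of the assay rather than a number. Compound 2 `Fc1ccc(-c2nc3sc(Cc4ccc(Cl)cc4)nn3c2Br)cc1` carries bromo in place of hydrogen on an aromatic carbon of the shared core. In this assay compound 2 gives > 250000 nM, again a limit of the assay. The step that the two limits leave unreadable from compound 1 to compound 2 cannot be read, since both values sit at the limit of > 250000 nM in this assay, at which 2 of the 2 values shown sit. Compound 2 thus stands at the limit of the assay, and no number separates it from compound 1.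

Compound 3 `O=Cc1c(-c2ccc(F)cc2)nc2sc(Cc3ccc(Cl)cc3)nn12` differs from compound 2 by formyl in place of bromo on an aromatic carbon. Among the compounds with values here, the only measured step, a step that the two limits leave unreadable from compound 1 to compound 2, touches the same aromatic carbon but offers no readable size, so the exchange of bromo for formyl has no measured precedent here. No step beyond the scatter in this assay can be expected in either direction. Compound 3 is accordingly estimated at 300000 nM, with a range from 100000 nM to 1000000 nM, and most likely it will again be reported only as a limit. The step implied by this estimate, a step that the limit leaves unreadable from compound 2 to compound 3, is expected to lie within the scatter.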

Compound 3, half-maximal inhibitory concentration: 20000 nM
Compound 3: middle estimate off by 15-fold (1.18 log units), on the high side, and the stated range ends above it.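

The aromatic carbon next to the ring nitrogen proves to be a place where this assay can respond to a change of group: formyl in place of bromo gives an at least 12-fold lower number from compound 2 to compound 3 (1.09 log units; beyond the scatter), and formyl in place of hydrogen gives an at least 12-fold lower number from compound 1 to compound 3 (1.09 log units; beyond the scatter). Within the data shown here, the earlier pair could not show this, as the step between hydrogen and bromo cannot be read, and compound 3 is the first compound here with a number rather than a limit. Both new steps are bounded on one side only, since each starts from a compound that stands at the limit: the limit of > 250000 nM in this assay, at which 2 of the 3 values shown sit.

Going by these compounds, it remains open whether this gain belongs to the formyl group alone or would also appear with an acetyl group, a hydroxymethyl group or a carboxylic acid on the same aromatic carbon. Also open, on these data alone, is whether formyl would give a step of similar size if a plain phenyl or a 4-methoxyphenyl group took the place of the 4-fluorophenyl group that all three compounds carry.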